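A few compounds are considered here, and "the series" means these few. Any claim that something is new, unique, unknown or untested is made for them only; others in the source may bear on it.

Measured so far in an assay on CHO cells for displacement of a labelled ligand from adenosine receptor A1 (Homo sapiens), read by scintillation counting, tested at 10 uM; a higher number here means more inhibition at the concentration tested (going by the name of the read-out), a lower number less inhibition:
Compound 1 `CNC(=O)[C@@]12C[C@@H]1[C@@H](n1cnc3c(NCc4cccc(Cl)c4)nc(C#CCCCCc4cn(-c5ccc(N)cc5)nn4)nc31)[C@H](O)[C@@H]2O` gives 3%.
Compound 2 `CNC(=O)[C@@]12C[C@@H]1[C@@H](n1cnc3c(NCc4cccc(Cl)c4)nc(C#CCCCCc4cn(-c5ccc(C(=O)O)cc5)nn4)nc31)[C@H](O)[C@@H]2O` gives 0%.
Compound 3 `CNC(=O)[C@@]12C[C@@H]1[C@@H](n1cnc3c(NCc4cccc(Cl)c4)nc(C#CCCCCc4cn(CCNC(C)=O)nn4)nc31)[C@H](O)[C@@H]2O` gives 12%.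

Compound 3 has the highest of the three numbers in this assay. Its nearest neighbour is compound 1, where the difference a number 9 percentage points higher from compound 1 to compound 3 (within the scatter) stays inside the usual scatter; the more distant one is compound 2, where the difference a number 12 percentage points higher from compound 2 to compound 3 (beyond the scatter) lies beyond it, though only modestly. Between compound 1 and compound 2 the change a number 3 percentage points lower from compound 1 to compound 2 (within the scatter) is within the scatter, so the two aryl-bearing compounds cannot be told apart.

Compound 4 `CNC(=O)[C@@]12C[C@@H]1[C@@H](n1cnc3c(NCc4cccc(Cl)c4)nc(C#CCCCCc4cn(-c5cccc([N+](=O)[O-])c5)nn4)nc31)[C@H](O)[C@@H]2O` is not yet measured. It differs from compound 3 as follows: 3-nitrophenyl in place of 2-acetamidoethyl on an aromatic nitrogen. The two measured steps that bear on this change run the other way, from an aryl group on that ring nitrogen to the 2-acetamidoethyl group, and both went up, one within the scatter and one just beyond it. Returning to an aryl group, now a 3-nitrophenyl, is therefore expected to bring the number back toward those of compound 1 and compound 2, giving a step of a number 8 percentage points lower from compound 3 to compound 4 (within the scatter) that is expected to be small and downward, at the edge of the scatter. In this assay compound 4 is estimated at 4%, within a range from 0% to 14%.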

Compound 4, a percentage reported as inhibition, at one concentration (the size of the read-out at that concentration, not a potency): 8%
Compound 4: middle estimate off by 4 percentage points, on the low side, and the stated range covers the measured number.
By their numbers in this assay, from the lowest: compounds 2, 1, 4 and 3 (each within the scatter of the next, the first and the last beyond it).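

In this assay, among the compounds shown here, the new 3-nitrophenyl compound weakens the one distinction the earlier compounds offered at this ring nitrogen, that of an aryl group from the 2-acetamidoethyl group, since the change gives a number 4 percentage points lower from compound 3 to compound 4 (within the scatter) and so cannot be separated from the 2-acetamidoethyl compound. It also stays inside the scatter of both other aryl compounds, with a number 8 percentage points higher from compound 2 to compound 4 (within the scatter) and a number 5 percentage points higher from compound 1 to compound 4 (within the scatter), so swapping one substituted phenyl for another, with the substituent and its ring position changing together, makes no readable difference here. For the compounds shown here, only the step from compound 2 to compound 3 still lies beyond the scatter, and nothing given here explains that gap or links it to any feature of these groups.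

The compounds shown leave open whether an unsubstituted phenyl or a 4-nitrophenyl would read any differently from the 3-nitrophenyl group, which would separate the nitro group from its ring position. They also leave open whether a small alkyl group such as methyl, a longer chain or a free primary amine at the end of the ethyl chain on this nitrogen would move the number beyond this narrow band.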